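Substituent swap on the fused ring of compound 1

This account rests on a few compounds, and the source may have more. Where it says the series, first, only, none or still open, it means among the compounds named here.

Compound 1 `NS(=O)(=O)c1ccc(Nc2nccc(Nc3nc4ccc(F)cc4s3)n2)cc1` stands lowest of the three numbers in a functional assay on HeLa cells (Homo sapiens) for antiproliferative activity, read by MTT assay, with a stated time of 48 h (a higher number here means a weaker inhibitor, a lower number a stronger inhibitor), at 450 nM. Compound 2 `CS(=O)(=O)c1ccc(Nc2nccc(Nc3nc4ccc(Cl)cc4s3)n2)cc1` gives 1400 nM and compound 3 `CS(=O)(=O)c1ccc(Nc2nccc(Nc3nc4ccccc4s3)n2)cc1` gives 11300 nM. Within the data shown here, the only single-point step measured, an 8.1-fold higher number from compound 2 to compound 3 (0.91 log units; beyond the scatter), shows that the group on this aromatic carbon matters. Compound 4 `Cc1ccc2nc(Nc3ccnc(Nc4ccc(S(N)(=O)=O)cc4)n3)sc2c1` differs from compound 1 by methyl in place of fluoro on an aromatic carbon. Among the measured compounds shown here, no measured step exchanges fluoro for methyl, and compound 1 and compound 2 differ in more than one place, so their gap cannot be assigned. Here a substituent is retained rather than removed. The step in this assay is therefore expected to be small, in either direction, likely within the scatter. Compound 4 is therefore expected at 500 nM, with a range of 150 nM to 1600 nM, an expected step of a 1.1-fold higher number from compound 1 to compound 4 (0.05 log units; within the scatter).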

Compound 4, half-maximal inhibitory concentration: 660 nM
The estimate for compound 4 lay 1.3-fold (0.12 log units) below the measured number; measured number inside the range.
By their numbers in this assay, from the lowest: compounds 1 and 4 (each within the scatter of the next); then compound 2; then compound 3.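

In this assay, methyl in place of fluoro on this aromatic carbon gives a 1.5-fold higher number from compound 1 to compound 4 (0.17 log units; within the scatter) and so does not separate the two groups. The earlier step, with hydrogen in place of chloro, showed that this carbon can matter; this step shows that one substituent can replace another here without a change beyond the scatter. No measurement bears on why the two groups read alike.

On these data alone, whether a methoxy group, an amine or a carboxylic acid on this carbon would hold the number remains open. So does the effect of hydrogen here in the core of compound 1.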